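Benzyl ether substituent swap, compound 1 to compound 3

This account rests on a few compounds, and the source may have more. Where it says the series, first, only, none or still open, it means among the compounds named here.

Two members of the series have been measured in an assay on V79MZh11B2 cells for inhibition of cytochrome P450 11B2, mitochondrial (Homo sapiens), read by HPLC, with a stated time of 25 min; a lower number here means a stronger inhibitor, a higher number a weaker inhibitor. Compound 1 `O=c1cc(Cn2ccnc2)c2ccc(OCc3cccc(Cl)c3)cc2o1` gives 101 nM, and compound 2 `O=c1cc(Cn2ccnc2)c2ccc(OCc3cccc(C(F)(F)F)c3)cc2o1` gives 150 nM. For the measured compounds named here, compound 1 holds the lowest of the two numbers, with compound 2 as its only neighbour; the step of a 1.5-fold higher number from compound 1 to compound 2 (0.17 log units; within the scatter) lies within the scatter, so the two compounds cannot be placed in order by these numbers.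

Compound 3 `O=c1cc(Cn2ccnc2)c2ccc(OCc3cc(F)cc(F)c3)cc2o1` has not yet been measured. It differs from compound 1 by 3,5-difluorophenyl in place of 3-chlorophenyl on a saturated chain carbon bound to an oxygen on an aromatic ring. Going by the values given here, the single measured step that bears on this change is a 1.5-fold higher number from compound 1 to compound 2 (0.17 log units; within the scatter), in which one substituent on the same benzyl ring was exchanged for another and the number did not move beyond the scatter. Among the compounds with values here, no compound carrying two substituents on that ring has been measured, so the expectation rests on that one step alone. For compound 3 the expected step of a 1.3-fold higher number from compound 1 to compound 3 (0.11 log units; within the scatter) is therefore small, with no direction beyond the scatter claimed. Compound 3 is estimated to give 130 nM in this assay, expected between 60 nM and 300 nM.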

Compound 3, half-maximal inhibitory concentration: 200 nM
For compound 3 the middle estimate is 1.5-fold (0.19 log units) below the measured one; low and high end bracket the measured number.
By their numbers in this assay, from the lowest: compounds 1, 2 and 3 (each within the scatter of the next).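

In this assay, putting 3,5-difluorobenzyl in place of 3-chlorobenzyl gives a 2.0-fold higher number from compound 1 to compound 3 (0.30 log units; within the scatter), so this position on the saturated chain carbon bound to an oxygen on an aromatic ring accepts a ring with two substituents without the number moving beyond the scatter. Compound 1 and compound 2 showed this only for an exchange of one substituent for another; read alongside that step, a 1.5-fold higher number from compound 1 to compound 2 (0.17 log units; within the scatter), the present result extends the same flat reading to a change in the number and kind of halogens on the ring. No accompanying data bear on this result, so the step stands as a measured number with nothing to account for it.

The compounds shown leave open whether a benzyl ring carrying an amine, a carboxylic acid or a methoxy group would also stay within the scatter of compound 1. They also leave open how a 3-fluorobenzyl or a plain benzyl group would read, which would separate the exchange of chloro for fluoro from the addition of a second substituent, and whether a longer chain between the oxygen and the ring is accepted.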